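The compounds below may be only part of what the source reports. "The series", "measured", "known", "first", "only" and "open" are said of these compounds alone.

Working notes on the series.

Three compounds share one core and differ only in the group on an aromatic carbon. Compound 1 `O=C(O)/C=C/C(=O)c1ccc(F)cc1` gives 16900 nM in a functional assay on K562 cells (Homo sapiens) for inhibition, read by MTT assay, with a stated time of 72 h; on this read-out higher numbers stand for weaker inhibition and lower numbers for stronger inhibition. Compound 2 `O=C(O)/C=C/C(=O)c1ccc(Cl)cc1` gives 21700 nM in this assay, and compound 3 `O=C(O)/C=C/C(=O)c1ccc(Br)cc1` gives 11200 nM in this assay. The three halogen swaps move little: a 1.3-fold higher number from compound 1 to compound 2 (0.11 log units; within the scatter), a 1.5-fold lower number from compound 1 to compound 3 (0.18 log units; within the scatter) and a 1.9-fold lower number from compound 2 to compound 3 (0.29 log units; within the scatter). Compound 3 holds the lowest of the three numbers, but its gaps to compound 1 and to compound 2 both sit inside the scatter, so no order among the three can be read from these data.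

Compound 4 `CC(C)c1ccc(C(=O)/C=C/C(=O)O)cc1` is not yet measured. It differs from compound 3 in one place: isopropyl in place of bromo on an aromatic carbon. Going by the values given here, none of the measured steps exchanges a halogen for an alkyl group, so no step bears directly on this change; the only guidance is that every change made so far at this aromatic carbon has stayed within the scatter. On that basis no step beyond the scatter is expected in this assay for compound 4, which is estimated at 12000 nM, with a range from 4500 nM to 32000 nM. The step this estimate implies is a 1.1-fold higher number from compound 3 to compound 4 (0.03 log units; within the scatter), which is expected to be small.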

Compound 4, half-maximal inhibitory concentration: 5560 nM
Beside the measured number, compound 4's estimate is 2.2-fold (0.33 log units) above it, within the range that was stated.
By their numbers in this assay, from the lowest: compounds 4, 3, 1 and 2 (each within the scatter of the next, the first and the last beyond it).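

In this assay, going by these compounds alone, the exchange of bromo for isopropyl gives a 2.0-fold lower number from compound 3 to compound 4 (0.30 log units; within the scatter), so this one change cannot be told apart from repeat measurement, yet the same group gives a 3.9-fold lower number from compound 2 to compound 4 (0.59 log units; beyond the scatter) and a 3.0-fold lower number from compound 1 to compound 4 (0.48 log units; beyond the scatter), the first steps at this aromatic carbon that lie beyond the scatter. The position therefore does respond to the group it carries, and a group of 3 carbon atoms is accepted in place of a single halogen atom with no loss on this read-out, though compound 4 stands apart only from the chloro and fluoro compounds and not from the bromo compound. Nothing at hand bears on why the number moves with this change.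

With isopropyl as the only alkyl group here, the compounds shown leave open whether methyl, tert-butyl or a longer chain at this carbon would go the same way, and how a methoxy group or an amine would compare. Going by these compounds, they also keep the carboxylic acid throughout, so what an ester or an amide in its place would do to these numbers remains open.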